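Methyl in place of cyano on a selenium

This account rests on a few compounds, and the source may have more. Where it says the series, first, only, none or still open, it means among the compounds named here.

Measured in a functional assay on HCT-116 cells (Homo sapiens) for inhibition, read by MTT assay, with a stated time of 48 h; a lower number here means a stronger inhibitor, a higher number a weaker inhibitor:
Compound 1 (`Cc1nc(N(C)c2ccc([Se]C#N)c(C)c2)c2ccccc2n1`) gives 13 nM
Compound 2 (`Cc1nc(N(C)c2ccc([Se]C#N)c(Cl)c2)c2ccccc2n1`) gives 12 nM
Compound 3 (`Cc1nc(N(C)c2ccc([Se]C#N)c(F)c2)c2ccccc2n1`) gives 20 nM

Compound 1 cannot be told apart from the other two measured compounds. The data show a 1.1-fold lower number from compound 1 to compound 2 (0.03 log units; within the scatter) and a 1.5-fold higher number from compound 1 to compound 3 (0.19 log units; within the scatter), along with a 1.7-fold higher number from compound 2 to compound 3 (0.22 log units; within the scatter), and all three steps lie within the scatter.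

Compound 4 (`C[Se]c1ccc(N(C)c2nc(C)nc3ccccc23)cc1C`) keeps the core of compound 1 and differs from it as follows: methyl in place of cyano on a selenium. Going by the values given here, none of the measured steps touches the selenium. They exchange methyl, chloro and fluoro on an aromatic carbon, so they bear on this change only indirectly and give no measure of its size. The central expectation in this assay is therefore no shift beyond the scatter, held with wide margins in both directions. The expected step is a 1.5-fold higher number from compound 1 to compound 4 (0.19 log units; within the scatter), and this estimate is loose. The estimated value for compound 4 is 20 nM, with an expected range from 4 nM to 120 nM.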

Compound 4, half-maximal inhibitory concentration: 3 nM
For compound 4 the middle estimate is 6.7-fold (0.82 log units) above the measured one; the measured number lies below the stated range.
By their numbers in this assay, from the lowest: compound 4; then compounds 2, 1 and 3 (each within the scatter of the next).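

In this assay, the group on the selenium proves to be a place where a single exchange registers: methyl in place of cyano gives a step beyond the scatter (a 4.3-fold lower number from compound 1 to compound 4 (0.64 log units; beyond the scatter)). The exchanges of methyl, chloro and fluoro on an aromatic carbon among compounds 1, 2 and 3 had all stayed within the scatter, so this is the first change shown to move the number. The cyano group on the selenium is also shown to be dispensable for a low number in this series, but no measurement is available that explains the step. On these data alone, what an ethyl, a longer chain or a benzyl on the selenium would give remains open. So does whether methyl in place of cyano has the same effect with the chloro of compound 2 or the fluoro of compound 3.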